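Notes on pyridin-2-yl replacing the aryl group of compound 1

The source may hold more compounds than are shown below. What is called first, only, known or untested is meant among the compounds shown, and "the series" means these compounds.

compound 1 `COc1ccc(C(=O)/C=C/c2ccc(N(C)C)cc2)c2c1C=CC(C)(C)O2` gives 2750 nM
compound 2 `COc1ccc(C(=O)/C=C/c2ccc(-c3ccccc3)cc2)c2c1C=CC(C)(C)O2` gives > 10000 nM (a limit)
compound 3 `CCN(CC)c1ccc(/C=C/C(=O)c2ccc(OC)c3c2OC(C)(C)C=C3)cc1` gives 610 nM

In a functional assay on SK-OV-3 cells (Homo sapiens) for antiproliferative activity, read by MTT assay, with a stated time of 24 h (a higher number here means a weaker inhibitor, a lower number a stronger inhibitor), compound 1 has the higher of the two actual numbers, and compound 3 gives 610 nM. The result for compound 2 is a limit, not a number. Compound 4 `COc1ccc(C(=O)/C=C/c2ccccn2)c2c1C=CC(C)(C)O2` differs from compound 1 as follows: pyridin-2-yl in place of 4-(dimethylamino)phenyl on a double-bonded chain carbon bound to a double-bonded chain carbon. Within the data shown here, two measured steps bear on this change only indirectly. Replacing dimethylamino with phenyl gave an at least 3.6-fold higher number from compound 1 to compound 2 (0.56 log units; beyond the scatter), whereas diethylamino gave a 4.5-fold lower number from compound 1 to compound 3 (0.65 log units; beyond the scatter). Compound 4 also lacks the dimethylamino group, as compound 2 does, so a modest step towards a higher number is expected. The expected change is a 2.5-fold higher number from compound 1 to compound 4 (0.41 log units; beyond the scatter). Compound 4 is estimated at 7000 nM, with an expected range of 2500 nM to 20000 nM.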

Compound 4, half-maximal inhibitory concentration: 8390 nM
Compound 4: the middle estimate sits 1.2-fold (0.08 log units) below what was measured; low and high end bracket the measured number.
By their numbers in this assay, from the lowest: compound 3; then compound 1; then compound 4. At a limit, above all of these: compound 2.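

In this assay, pyridin-2-yl in place of 4-(dimethylamino)phenyl gives a 3.1-fold higher number from compound 1 to compound 4 (0.48 log units; beyond the scatter). The earlier steps shown here changed only the group on the aromatic ring, whereas this one exchanges the whole aryl group at the chain carbon, and compound 4 still gives a number with no dimethylamino or diethylamino group present. The result for compound 2 is a limit, not a number: the limit of > 10000 nM in this assay, at which 1 of the 4 values shown sits.

The compounds shown do not separate the loss of the dimethylamino group from the entry of the ring nitrogen. Unsubstituted phenyl at this chain carbon, or pyridin-2-yl carrying a dimethylamino group, would address that question.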